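A few compounds are considered here, and "the series" means these few. Any claim that something is new, unique, unknown or untested is made for them only; others in the source may bear on it.

In an ADME assay on microsomes from liver (Homo sapiens) for metabolic stability, read by LC-MS, with a stated time of 1 h, tested at 5 uM, in the presence of a further agent that is not named here (a lower number here means that less of the compound is left, a higher number that more of the compound is left), compound 1 (`O=C(O)c1ccc(NCc2c(-c3c(Cl)cccc3C(F)(F)F)noc2-c2ccco2)cc1`) gives 92.8%. Going by the values given here, the only other measured compound, compound 2 (`O=C(O)c1ccc(NC(=O)c2c(-c3c(Cl)cccc3C(F)(F)F)noc2-c2ccccc2)cc1`), gives 100%. These two values lie within the usual scatter of each other, so the measurements do not separate the two compounds.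

Compound 3 (`O=C(O)c1ccc(NCc2c(-c3c(Cl)cccc3C(F)(F)F)noc2-c2cc[nH]c2)cc1`), which has not yet been measured, keeps the core of compound 1 and changes one ring: 1H-pyrrol-3-yl in place of furan-2-yl on an aromatic carbon. In words, it carries 1H-pyrrol-3-yl in place of furan-2-yl on an aromatic carbon.

Among the compounds with values here, no measured pair shows what a swap of this kind does in this assay, so any expectation here is loose and the range has to be wide. Compound 1 at 92.8% leaves little room for a rise on this read-out. Any shift that appears is therefore more likely to be downward, and it is expected to be modest, close to the size of the scatter. In numbers, the estimate is a number 6.8 percentage points lower from compound 1 to compound 3 (within the scatter). For compound 3 the expected value is 86%, with an estimated range from 65% to 100%.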

Compound 3, percent of the compound remaining in the Homo sapiens assay: 69.8%
Compound 3: the middle estimate sits 16.2 percentage points above what was measured; low and high end bracket the measured number.
By their numbers in the Homo sapiens assay, from the lowest: compound 3; then compounds 1 and 2 (each within the scatter of the next).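

In the Homo sapiens assay, placing 1H-pyrrol-3-yl in place of furan-2-yl on this aromatic carbon, next to the ring oxygen, takes compound 1 at 92.8% to compound 3 at 69.8%, which gives a number 23 percentage points lower from compound 1 to compound 3 (beyond the scatter). Going by these compounds alone, this is the first single-place step, and it shows that the ring held at this position can matter for how much compound remains, something compounds 1 and 2 could not show because they differ in more than one place. In a physicochemical assay, read by LC-MS, with a stated time of 24 h, at pH 7.4, tested at 2 uM (on this read-out lower numbers stand for a less stable compound and higher numbers for a more stable compound), the same change gives a number 4.7 percentage points lower from compound 1 to compound 3 (within the scatter), with compound 1 at 100% and compound 3 at 95.3%, so the step beyond the scatter appears only in the Homo sapiens assay, and no measurement at hand gives a reason for it.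

The swap changes several things at once: the ring hetero atom goes from oxygen to nitrogen, the attachment point on the ring differs, and a hydrogen-bond donor enters, so this single step cannot say which of these matters. A furan-3-yl or a 1H-pyrrol-2-yl group would separate the hetero atom from the attachment point, while a thiophen-2-yl group would test a third hetero atom at this position.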